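The compounds below may be only part of what the source reports. "The series", "measured", "known", "first", "only" and "open" are said of these compounds alone.

Going by the values given here, compound 2 `CS(=O)(=O)c1ccc(-c2csc(N3N=C(c4ccc(Cl)s4)CC3c3ccc(F)cc3)n2)cc1` is one of three compounds so far tested in an ADME assay on NIH3T3 cells (Mus musculus) for cytotoxicity, read by XTT assay, with a stated time of 24 h; a higher number here means a weaker inhibitor, a lower number a stronger inhibitor. In this assay compound 2 gives > 500 ug/mL, which is a limit of the assay rather than a number. Compound 1 `Cc1ccc(C2=NN(c3nc(-c4ccccc4)cs3)C(c3ccc(F)cc3)C2)s1` likewise gives > 500 ug/mL in this assay, again a limit. Compound 3 `Cc1ccc(C2=NN(c3nc(-c4ccc(S(C)(=O)=O)cc4)cs3)C(c3ccc(F)cc3)C2)s1` gives 374 ug/mL in this assay. Compound 2 therefore sits at the limit of > 500 ug/mL in this assay, at which 2 of the 3 values shown sit. Compound 4 `Cc1ccc(-c2csc(N3N=C(c4ccc(Cl)s4)CC3c3ccc(F)cc3)n2)cc1` differs from compound 2 in one place: methyl in place of methylsulfonyl on an aromatic carbon. Among the compounds with values here, two measured steps bear on this change. The step of an at least 1.3-fold lower number from compound 1 to compound 3 (0.12 log units; that floor lies within the scatter) adds a methylsulfonyl group, and the step of an at least 1.3-fold lower number from compound 2 to compound 3 (0.12 log units; that floor lies within the scatter) exchanges chloro for methyl; both carry a floor that lies within the scatter. Because the step of an at least 1.3-fold lower number from compound 1 to compound 3 (0.12 log units; that floor lies within the scatter) ran the other way, adding methylsulfonyl, removing it is expected to leave the number at the limit or move it upward. The step from compound 2 to compound 4 is expected to be a step that the limit leaves unreadable from compound 2 to compound 4, nothing beyond the scatter. Compound 4 is estimated at 600 ug/mL, within 350 ug/mL to 1200 ug/mL, and most likely reported again only as a limit.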

Compound 4, half-maximal inhibitory concentration: > 500 ug/mL
Compound 4: no number, only a limit (the forecaster's own chance of this, stated with the estimate: 85%); the middle value is on the limit's open side.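

In this assay compound 4 gives > 500 ug/mL, which is a limit of the assay and not a number. Compound 2 also stands at a limit, so the step between compound 2 and compound 4 cannot be read. The compounds shown leave open whether methyl in place of methylsulfonyl changes the number at all.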